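Swapping the Chlorine of Compound 3 for a Silicon Group

This account rests on a few compounds, and the source may have more. Where it says the series, first, only, none or still open, it means among the compounds named here.

In a functional assay on SW480 cells (Homo sapiens) for antiproliferative activity, read by MTT assay, with a stated time of 48 h (a higher number here means a weaker inhibitor, a lower number a stronger inhibitor), compound 1 (`CO[C@]1(C)/C=C/C(=O)/C(CO)=C\C[C@](C)(CCC=C(C)C)/C=C/[C@H]1OC(=O)C=C(C)C`) gives 15200 nM and compound 2 (`C=C1/C=C/C(=O)/C(CO)=C\C[C@](C)(CCC=C(C)C)/C=C/[C@H]1OC(=O)C=C(C)C`) gives 2970 nM. Compound 3 (`CC(C)=CCC[C@]1(C)/C=C/[C@@H](OC(=O)C=C(C)C)[C@](C)(O)/C=C/C(=O)/C(CCl)=C\C1`) gives 390 nM, the lowest of the three numbers and beyond the scatter of both others. Compound 4 (`CC[Si](CC)(CC)C/C1=C/C[C@](C)(CCC=C(C)C)/C=C/[C@@H](OC(=O)C=C(C)C)[C@](C)(O)/C=C/C1=O`), not yet measured, differs from compound 3 by a group of 7 heavy atoms (6 carbon, 1 silicon; no ring) in place of one chlorine atom, on a saturated chain carbon bound to a double-bonded ring carbon, on a saturated chain carbon bound to a double-bonded ring carbon. Within the data shown here, no measured pair differing in one place sizes this change. The expectation rests on compound 3 alone carrying the chlorine, at 390 nM, so a weakening beyond the scatter is expected. The expected move is a 6.4-fold higher number from compound 3 to compound 4 (0.81 log units; beyond the scatter). Compound 4 is estimated at 2500 nM, with an expected range of 600 nM to 10000 nM.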

Compound 4, half-maximal inhibitory concentration: 2690 nM
Beside the measured number, compound 4's estimate is 1.1-fold (0.03 log units) below it; the range from low to high includes it.
By their numbers in this assay, from the lowest: compound 3; then compounds 4 and 2 (each within the scatter of the next); then compound 1.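

Among these compounds, compound 4 gives the first single-place comparison at this position: in this assay, the silicon group of 7 heavy atoms in place of the chloro group produces a 6.9-fold higher number from compound 3 to compound 4 (0.84 log units; beyond the scatter), so this site on a saturated chain carbon bound to a double-bonded ring carbon responds to what it carries. The chlorine is thus not needed for a measurable number, though compound 3 retains the lower one. Nothing shown accounts for the size of this step. As far as these compounds go, it remains open how a bromo group, an amine or a tert-butyl group would read at this position, and therefore whether the silicon atom itself or the size of the group matters.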